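Working notes on compound 1 and its amide analogue compound 4

The compounds below may be only part of what the source reports. "The series", "measured", "known", "first", "only" and "open" are said of these compounds alone.

Compound 1 `CCS(=O)(=O)Nc1cccc2c1CCCC2c1c[nH]cn1` — 1320 nM
Compound 2 `CCS(=O)(=O)Nc1cccc2c1CCCC2CN` — < 10000 nM (a limit)
Compound 3 `CCS(=O)(=O)Nc1cc(F)cc2c1CCCC2c1c[nH]cn1` — < 10000 nM (a limit)

For the measured compounds named here, in an assay on isolated protein (Cricetulus griseus) for binding affinity to Alpha-1B adrenergic receptor (Mesocricetus auratus), read by radioligand binding (on this read-out lower numbers stand for stronger inhibition and higher numbers for weaker inhibition), compound 1 gives 1320 nM, the only number. For compound 2 the read-out is a limit of the assay, < 10000 nM. For compound 3 the read-out is likewise a limit, < 10000 nM. Both measured steps, a step that the limit leaves unreadable from compound 1 to compound 2 and a step that the limit leaves unreadable from compound 1 to compound 3, are unreadable in size because of the limit of < 10000 nM in this assay, at which 2 of the 3 values shown sit.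

Compound 4 `O=C(Nc1cccc2c1CCCC2c1c[nH]cn1)C(F)(F)F` differs from compound 1 in one place: (trifluoromethyl)carbonyl in place of ethylsulfonyl on a nitrogen on an aromatic ring. Going by the values given here, no measured step touches the nitrogen on an aromatic ring, so nothing here anchors this change. The expectation for compound 4 is therefore a step of a 1.5-fold higher number from compound 1 to compound 4 (0.18 log units; within the scatter) in this assay, not beyond the usual scatter. Compound 4 is expected to give 2000 nM, within 500 nM to 8000 nM.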

Compound 4, inhibition constant: < 10000 nM
Compound 4: no number, only a limit; the forecaster's own chance of this, stated with the estimate: 25%; the middle value does not contradict the limit.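

In this assay compound 4 gives < 10000 nM, a limit and not a number, so no new step from compound 1 to compound 4 can be read: the limit of < 10000 nM in this assay, at which 3 of the 4 values shown sit.

The compounds shown leave open how far compound 2, compound 3 and compound 4 each lie from compound 1 in this assay.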